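Methyl on the phenyl: does compound 4 stay tolerated?

The source may hold more compounds than are shown below. What is called first, only, known or untested is meant among the compounds shown, and "the series" means these compounds.

Three compounds have been measured in an ADME assay on RD cells (Homo sapiens) for cytotoxicity; a higher number here means that more compound is tolerated, a lower number that less compound is tolerated:

Compound 1 `O=C1Nc2ccc(OC(F)(F)F)cc2/C1=N/NC(=S)Nc1ccccc1` gives > 25000 nM, a limit of the assay.
Compound 2 `O=C(N/N=C1\C(=O)Nc2ccccc21)Nc1ccccc1` gives > 25000 nM, a limit of the assay.
Compound 3 `CN(C)C(=S)N/N=C1/C(=O)Nc2ccccc21` gives > 25000 nM, a limit of the assay.

Compound 2 therefore stands at the limit, not at a number, as do the other two values shown: the limit of > 25000 nM in this assay, at which 3 of the 3 values shown sit. Compound 4 `Cc1cccc(NC(=O)N/N=C2\C(=O)Nc3ccccc32)c1` differs from compound 2 in one place: methyl in place of hydrogen on an aromatic carbon. Among the measured compounds shown here, no step between two measured compounds is known here. Since nothing shown distinguishes the three compounds, the step from compound 2 to compound 4 in this assay is expected to be none beyond the scatter, and the limit is expected to recur. Compound 4 is estimated at 30000 nM, in the range 15000 nM to 60000 nM, meaning a step that the limit leaves unreadable from compound 2 to compound 4.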

Compound 4, half-maximal cytotoxic concentration: > 25000 nM
Compound 4: only a limit was reported; the forecaster's own chance of this, stated with the estimate: 85%; the middle value does not contradict the limit.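

Compound 2 and compound 4 both stand at a limit of this assay, so no step can be read between them: the limit of > 25000 nM in this assay, at which 4 of the 4 values shown sit.

The compounds shown leave open whether phenyl to 3-methylphenyl changes tolerance at all, as none of them gives a number.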